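This account rests on a few compounds, and the source may have more. Where it says the series, first, only, none or still open, it means among the compounds named here.

Compound 1 `CCOC(=O)c1sc(-c2nc3ccccc3n2C)nc1C` and compound 2 `CCOC(=O)c1sc(-c2nc3ccccc3n2CC)nc1C` share one core and differ only at a saturated chain carbon bound to an aromatic nitrogen, where compound 2 carries an ethyl group. In a functional assay on MCF7 cells (Homo sapiens) for cytotoxicity, read by MTT assay, with a stated time of 24 h (on this read-out lower numbers stand for stronger inhibition and higher numbers for weaker inhibition), compound 1 gives > 20000 nM, which is a limit of the assay and not a number. In this assay compound 2 gives > 20000 nM, again a limit rather than a number. The step that the two limits leave unreadable from compound 1 to compound 2 therefore cannot be sized, and the limit of > 20000 nM in this assay, at which 2 of the 2 values shown sit, is all that the two values show. Compound 3 `CCOC(=O)c1sc(-c2nc3ccccc3n2C(C)C)nc1C` continues along the same chain: methyl in place of hydrogen on a saturated chain carbon bound to an aromatic nitrogen and a saturated chain carbon. For the measured compounds named here, no measured step reads on this change, since the two values shown are both limits, so neither direction nor size can be drawn from them. The expected value for compound 3 is estimated at 30000 nM, with a range from 8000 nM to 100000 nM, and it is most likely to be reported only as a limit again. The expected step is a step that the limit leaves unreadable from compound 2 to compound 3.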

Compound 3, half-maximal inhibitory concentration: > 20000 nM
Compound 3: only a limit was reported; the forecaster's own chance of this, stated with the estimate: 85%; the middle value lies beyond the limit too.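

No step among compound 1, compound 2 and compound 3 can be read, since all three sit at the same limit rather than at a number: the limit of > 20000 nM in this assay, at which 3 of the 3 values shown sit.

Going by these compounds, whether the group on the aromatic nitrogen affects the read-out at all, and how potent any of the three compounds actually is, stays open.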